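Aryl swap on the aminopyridine core of compound 1

The source may hold more compounds than are shown below. What is called first, only, known or untested is meant among the compounds shown, and "the series" means these compounds.

Compound 1 `COc1cc(N(CC2CC2)c2cccc(C(F)(F)F)c2)cnc1C(=O)[C@H]1C[C@@H]1C(=O)O` is the reference point of this small set. In an assay on isolated protein for inhibition of leukotriene C4 synthase (Homo sapiens), read by LC-MS, with stated times of 45 min and 20 min (on this read-out higher numbers stand for weaker inhibition and lower numbers for stronger inhibition), compound 1 gives 52.4 nM, the lowest of the two numbers available, though its nearest neighbour, compound 3 `CCCN(c1cccc(C(F)(F)F)c1)c1cnc(C(=O)[C@H]2C[C@@H]2C(=O)O)c(OC)c1`, gives 58.4 nM, and the step of a 1.1-fold higher number from compound 1 to compound 3 (0.05 log units; within the scatter) lies within the scatter. Compound 2 `COc1cc(N(CC(C)(C)O)c2cccc(C(F)(F)F)c2)cnc1C(=O)[C@H]1C[C@@H]1C(=O)O` carries a different chain on the same nitrogen; in this assay compound 2 is recorded as "not determined" (no result reported), so no number is available for it. Compound 4 `COc1cc(N(CC2CC2)c2ccc(F)c(Cl)c2)cnc1C(=O)[C@H]1C[C@@H]1C(=O)O` differs from compound 1 by a single change: 3-chloro-4-fluorophenyl in place of 3-(trifluoromethyl)phenyl on a nitrogen on an aromatic ring. Among the measured compounds shown here, the only measured step, from compound 1 to compound 3, concerns the saturated chain carbon bound to the nitrogen, not the aryl ring, so no measured step bears directly on the change to compound 4. Without such guidance, the expected step of a 1.5-fold higher number from compound 1 to compound 4 (0.18 log units; within the scatter) is small and carries a wide uncertainty. Compound 4 is therefore estimated at 80 nM in this assay, with an expected range from 25 nM to 250 nM.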

Compound 4, half-maximal inhibitory concentration: 42.3 nM
For compound 4 the middle estimate is 1.9-fold (0.28 log units) above the measured one; low and high end bracket the measured number.
By their numbers in this assay, from the lowest: compounds 4, 1 and 3 (each within the scatter of the next).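

Among the compounds shown here, compound 4 gives the first measured step at the aryl group on the nitrogen, since the earlier comparison concerned only the saturated chain. In this assay the exchange of 3-(trifluoromethyl)phenyl for 3-chloro-4-fluorophenyl gives a 1.2-fold lower number from compound 1 to compound 4 (0.09 log units; within the scatter) and so leaves the two aryl groups indistinguishable on this read-out. With the chain of compound 1 on the nitrogen, a trifluoromethyl group is therefore not needed for a number of this size, and nothing available here explains why the two aryl groups read alike.

The compounds shown leave open how an aryl ring bearing a nitrile or an amine would read at this place. They also leave open whether 3-chloro-4-fluorophenyl would read the same with the chain of compound 3 on the nitrogen.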